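Shifting a hydroxyl group across two related cores

This account rests on a few compounds, and the source may have more. Where it says the series, first, only, none or still open, it means among the compounds named here.

Four compounds are compared in a functional assay on HCT-15 cells (Homo sapiens) for inhibition; on this read-out higher numbers stand for weaker inhibition and lower numbers for stronger inhibition. Compound 1 `Oc1cccc(-c2cc(-c3ccccc3OC(F)(F)F)cc(-c3ccccc3O)n2)c1` gives 3240 nM. Compound 2 `Oc1ccc(-c2cc(-c3ccccc3OC(F)(F)F)cc(-c3ccccc3O)n2)cc1` gives 9820 nM. The two differ by 4-hydroxyphenyl in place of 3-hydroxyphenyl on an aromatic carbon, and this change gave a 3.0-fold higher number from compound 1 to compound 2 (0.48 log units; beyond the scatter).

Compound 3 `Oc1cccc(-c2cc(-c3cccc(OC(F)(F)F)c3)cc(-c3cccc(O)c3)n2)c1` is built on a different core; the difference between the two cores is not broken down here. In this assay compound 3 returned only > 50000 nM, which is a limit of the assay and not a number (the limit of > 50000 nM in this assay, at which 1 of the 3 values shown sits).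

Compound 4 `Oc1ccc(-c2cc(-c3cccc(OC(F)(F)F)c3)cc(-c3cccc(O)c3)n2)cc1` has not yet been measured. It differs from compound 3 by 4-hydroxyphenyl in place of 3-hydroxyphenyl on an aromatic carbon. The surroundings are not identical: in compound 1 the place is meta to a 2-hydroxyphenyl group, in compound 3 it is meta to a 3-hydroxyphenyl group, so this is the same kind of change rather than the same change.

Because the same kind of change gave a 3.0-fold higher number from compound 1 to compound 2 (0.48 log units; beyond the scatter), the step is expected to be a step that the limit leaves unreadable from compound 3 to compound 4, weakening further. Compound 4 is therefore expected to give 120000 nM, roughly between 50000 nM and 400000 nM, most likely reported again only as a limit.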

Compound 4, half-maximal inhibitory concentration: 1730 nM
Estimate against measurement, compound 4: 69-fold (1.84 log units) above; the whole stated range lies above it.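

In this assay, 4-hydroxyphenyl in place of 3-hydroxyphenyl gave an at least 28-fold lower number from compound 3 to compound 4 (1.46 log units; beyond the scatter), so this kind of change ran in the opposite direction to the earlier step. Neither the size nor the direction of the change carried over from one core to the other: the same change on two cores in this assay, a 3.0-fold higher number (0.48 log units; beyond the scatter) from compound 1 to compound 2 and an at least 28-fold lower number (1.46 log units; beyond the scatter) from compound 3 to compound 4, at least 87-fold (1.94 log units) apart, beyond the scatter of two such steps Two pairs cannot show which difference between the cores lies behind this reversal, nor how the change would behave on any further core, so the result from one core is a poor guide to another in this series.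

As far as these compounds go, the exact size of the new step stays open: compound 3 gives > 50000 nM, which is a limit of the assay and not a number. Also open, from the compounds shown here alone, is how each core would respond if a methoxy group or an amine took the place of the hydroxyl on the ring that carries this change.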